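A few compounds are considered here, and "the series" means these few. Any claim that something is new, unique, unknown or untested is made for them only; others in the source may bear on it.

Measured compounds in a functional assay on RPMI-8226 cells (Homo sapiens) for inhibition, read by sulforhodamine B assay, with a stated time of 48 h, tested at 10 uM; a lower number here means less inhibition, a higher number more inhibition at the concentration tested (going by the name of the read-out):

Compound 1 `c1ccc(-c2cn3ccnc3c(-c3ccc4ncn(C5CCCCC5)c4c3)n2)cc1`: 85.7%
Compound 2 `O=Cc1ccc(-c2cn3ccnc3c(-c3ccc4ncn(C5CCCCC5)c4c3)n2)cc1`: 82.5%
Compound 3 `Clc1ccc(-c2cn3ccnc3c(-c3ccc4ncn(C5CCCCC5)c4c3)n2)cc1`: 19%

Compound 3 stands lowest of the three numbers in this assay. Compound 1 gives 85.7% and compound 2 gives 82.5%; the step of a number 3.2 percentage points lower from compound 1 to compound 2 (within the scatter) lies within the scatter. Against these, the steps of a number 66.7 percentage points lower from compound 1 to compound 3 (beyond the scatter) and a number 63.5 percentage points lower from compound 2 to compound 3 (beyond the scatter) are large, and both put the chloro compound far below the other two.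

Compound 4 `Brc1ccc(-c2cn3ccnc3c(-c3ccc4ncn(C5CCCCC5)c4c3)n2)cc1` differs from compound 3 by bromo in place of chloro on an aromatic carbon. Going by the values given here, no measured step swaps one halogen for another, so the two steps that bear on it are a number 66.7 percentage points lower from compound 1 to compound 3 (beyond the scatter) and a number 63.5 percentage points lower from compound 2 to compound 3 (beyond the scatter), and they bear only indirectly: they show where a halogen at this place leaves the number, not how bromo compares with chloro. With one halogen for another of the same kind of attachment, the step of a number 6 percentage points higher from compound 3 to compound 4 (within the scatter) is expected to be small or none beyond the scatter. Compound 4 is therefore estimated at 25%, with a range from 5% to 55%.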

Compound 4, a percentage reported as inhibition, at one concentration (the size of the read-out at that concentration, not a potency): 32.1%
Compound 4: the middle estimate sits 7.1 percentage points below what was measured; the measured number falls inside the stated range.
By their numbers in this assay, from the lowest: compound 3; then compound 4; then compounds 2 and 1 (each within the scatter of the next).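

In this assay, going by these compounds alone, the change from 4-chlorophenyl to 4-bromophenyl gives a number 13.1 percentage points higher from compound 3 to compound 4 (beyond the scatter), the first measured step between two halogens here, so the two are not interchangeable at this place. Bromo nevertheless stays far under both other groups, with a number 50.4 percentage points lower from compound 2 to compound 4 (beyond the scatter) and a number 53.6 percentage points lower from compound 1 to compound 4 (beyond the scatter), so both halogens tested give a low number, whereas formyl, the one other substituent shown, goes against any general loss on substitution. Nothing available explains these steps.

Fluoro, the smallest halogen, remains open, as does iodo, so it is unclear whether the rise from chloro to bromo continues along the halogens. An amine, a methoxy group or a carboxylic acid at this place could show whether the level of formyl and hydrogen extends to other non-halogen groups.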